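Methyl Gives Way to Methoxycarbonyl on the Shared Core

The source may hold more compounds than are shown below. What is called first, only, known or untested is meant among the compounds shown, and "the series" means these compounds.

In a functional assay on MCF7 cells (Homo sapiens) for inhibition (on this read-out higher numbers stand for weaker inhibition and lower numbers for stronger inhibition), compound 1 `CCCCCCCC[C@@]1(C)SC(O)=C(C)C1=O` gives 16.5 ug/mL. Compound 2 `CCCCCC[C@@]1(C)SC(=O)C=C1OC` gives 14 ug/mL, and the two numbers lie within the scatter of each other, so compound 1 stands level with its nearest neighbour. Compound 3 `C=CCOC1=CC(=O)S[C@]1(C)CCCCCCCC` gives no number in this assay, only a limit of > 50 ug/mL. For the measured compounds named here, these three compounds are all that has been measured so far, and no pair among them differs in one place alone.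

The next compound, compound 4 `CCCCCCCC[C@@]1(C)SC(O)=C(C(=O)OC)C1=O`, keeps the core of compound 1 and its octyl-bearing side unchanged. It carries methoxycarbonyl in place of methyl on a double-bonded ring carbon, next to the ring atom that bears a hydroxy group (methoxycarbonyl in place of methyl on a double-bonded ring carbon). Going by the values given here, no measured step shows what this change does, so the expectation starts from compound 1 at 16.5 ug/mL and stays cautious. Only a small shift toward weaker inhibition is expected, one that does not clearly leave the scatter. The expected step is a 1.5-fold higher number from compound 1 to compound 4 (0.18 log units; within the scatter). A result at the limit of the assay also remains possible. Compound 4 is estimated at 25 ug/mL, with an expected range from 9 ug/mL to 50 ug/mL.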

Compound 4, half-maximal inhibitory concentration: 18.7 ug/mL
For compound 4 the middle estimate is 1.3-fold (0.13 log units) above the measured one, and the stated range covers the measured number.
By their numbers in this assay, from the lowest: compounds 2, 1 and 4 (each within the scatter of the next). At a limit, above all of these: compound 3.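

In this assay, methoxycarbonyl in place of methyl on a double-bonded ring carbon gives a 1.1-fold higher number from compound 1 to compound 4 (0.05 log units; within the scatter), and this is the first step shown between compounds that differ in one place. It shows that, with the hydroxy group and the octyl-bearing side of the shared core unchanged, this position can carry methoxycarbonyl, with its additional heavy atoms and hydrogen-bond acceptors, while compound 1 and compound 4 stay level with each other in this read-out. Compound 3 remains the only compound shown that gives a limit and not a number: the limit of > 50 ug/mL in this assay, at which 1 of the 4 values shown sits.

Going by these compounds, one step at one position cannot say how far this tolerance extends, so it remains open whether a carboxylic acid, an amide, an ethoxycarbonyl group or a hydrogen atom on the same ring carbon would also stay level with compound 1. It also remains open whether methoxycarbonyl would read the same way on a core with a longer chain in place of the octyl side, since the compounds shown offer no second pair that tests this change.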